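Swapping an ethylcarbamoyl for chloro on a diaryl ether core

The compounds below may be only part of what the source reports. "The series", "measured", "known", "first", "only" and "open" are said of these compounds alone.

Compound 1, with the structure `CCNC(=O)c1cc(N)c(Nc2ccc(C#N)cc2)cc1Oc1c(C)cc(CCC#N)cc1C`, is one of three closely related diaryl ether anilines examined for cytotoxicity. Among the compounds with values here, in an ADME assay on TZM cells (Homo sapiens) for cytotoxicity, with a stated time of 1 days (on this read-out higher numbers stand for lower toxicity in this test and lower numbers for higher toxicity in this test), compound 1 gives 105000 nM, which is the only plain number reported among the three. Compound 2, `Cc1cc(CCC#N)cc(C)c1Oc1cc(Nc2ccc(C#N)cc2)c(N)cc1CN1CCN(C)CC1`, has no value in this assay, shown as "not determined" (no result reported). Compound 3, `Cc1cc(CCC#N)cc(C)c1Oc1ccc(N)c(Nc2ccc(C#N)cc2)c1`, reaches only a limit in this assay, reported as > 200000 nM, and stands at the limit of > 200000 nM in this assay, at which 1 of the 3 values shown sits.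

Compound 4 has the structure `Cc1cc(CCC#N)cc(C)c1Oc1cc(Nc2ccc(C#N)cc2)c(N)cc1Cl`. It differs from compound 1 by chloro in place of ethylcarbamoyl on an aromatic carbon.

Within the data shown here, only one measured step bears on this change, the removal of the same ethylcarbamoyl group: an at least 1.9-fold higher number from compound 1 to compound 3 (0.27 log units; that floor lies within the scatter). That step points toward lower toxicity, but its floor lies within the usual scatter, so the direction is suggestive rather than settled. Chloro is a smaller substituent than ethylcarbamoyl, carrying neither hydrogen-bond donor nor acceptor, so the expected outcome for compound 4 is a number no lower than that of compound 1 and perhaps somewhat higher, as a 1.4-fold higher number from compound 1 to compound 4 (0.15 log units; within the scatter) indicates. Compound 4 is therefore estimated at 150000 nM, in a range from 60000 nM to 300000 nM.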

Compound 4, half-maximal cytotoxic concentration: 10400 nM
Compound 4: middle estimate off by 14-fold (1.16 log units), on the high side; the whole stated range lies above it.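

In this assay, the aromatic carbon para to a (4-cyanophenyl)amino group proves sensitive to the group it carries, as chloro in place of ethylcarbamoyl gives a 10-fold lower number from compound 1 to compound 4 (1.00 log units; beyond the scatter), a clear move toward higher toxicity in this test. The earlier step on removing ethylcarbamoyl stayed within the scatter at its floor, so it gave no sign of this, whereas chloro in place of hydrogen at the same carbon gives an at least 19-fold lower number from compound 3 to compound 4 (1.28 log units; beyond the scatter), which shows that the hydrogen and ethylcarbamoyl compounds both sit well above the chloro compound. That second step is only a floor, as compound 3 stands at a limit of the assay and not at a plain number: the limit of > 200000 nM in this assay, at which 1 of the 4 values shown sits.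

The compounds shown leave open whether a fluoro, a methyl or a methoxy group at this carbon would track chloro or stay with hydrogen and ethylcarbamoyl. They also leave open whether a carboxylic acid or an amide with a longer chain would keep the high number seen for ethylcarbamoyl.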